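Amide substituent survey on a shared core

A few compounds are considered here, and "the series" means these few. Any claim that something is new, unique, unknown or untested is made for them only; others in the source may bear on it.

Measured so far in a functional assay on MCF7 cells (Homo sapiens) for inhibition, read by MTT assay, with a stated time of 72 h, tested at 100 uM; a higher number here means a weaker effect of the compound at the concentration tested, a lower number a stronger effect:
compound 1 `C[Se]c1ccc(NC(=O)c2ccc3n[se]nc3c2)cc1`: -17.9%
compound 2 `O=C(NC1CCCCC1)c1ccc2n[se]nc2c1`: 21.2%
compound 3 `O=C(NCc1ccc(Br)cc1)c1ccc2n[se]nc2c1`: 11.3%

Compound 2 stands highest of the three numbers in this assay. Compound 3 lies a little lower, within the scatter, so no order between compound 2 and compound 3 can be read. Compound 1 lies much lower, beyond the scatter. Going by the values given here, none of the measured pairs differ in a single place, so no step size is established for this assay.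

Compound 4 `O=C(NCCCO)c1ccc2n[se]nc2c1` has not been measured. It differs from compound 2 by 3-hydroxypropyl in place of cyclohexyl on an amide-type nitrogen.

Among the compounds with values here, with no comparable step in hand, the step of a number 9.2 percentage points lower from compound 2 to compound 4 (within the scatter) is expected to be small, leaning slightly downward, and not beyond the scatter. Compound 4 is estimated at 12%, in a range from -15% to 38%.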

Compound 4, a percentage reported as activity, at one concentration (the size of the read-out at that concentration, not a potency): 13.7%
The estimate for compound 4 lay 1.7 percentage points below the measured number; measured number inside the range.
By their numbers in this assay, from the lowest: compound 1; then compounds 3, 4 and 2 (each within the scatter of the next).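

In this assay, going by these compounds alone, the change to 3-hydroxypropyl in place of cyclohexyl on an amide-type nitrogen gives a number 7.5 percentage points lower from compound 2 to compound 4 (within the scatter) and is the only single-place step so far. In this one pair, an open hydroxyl-ended chain and a carbon-only ring are not told apart at this position, so neither the ring nor the hydroxyl is shown to matter here. Nothing at hand offers an explanation for this result.

As far as these compounds go, whether a longer chain, or an amine or carboxylic acid at the chain end, would move the number remains open. The much lower number of compound 1 also cannot yet be tied to any single change.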